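The compounds below may be only part of what the source reports. "The series", "measured", "known", "first", "only" and "open" are said of these compounds alone.

Working notes on the series: compound 1 `COc1ccc(S(=O)(=O)NC(C2=CC(=O)c3c(O)ccc(O)c3C2=O)C(C)C)cc1`, compound 2 `CC(C)C(NS(=O)(=O)c1ccc(F)cc1)C1=CC(=O)c2c(O)ccc(O)c2C1=O` and compound 3 `COc1ccc(S(=O)(=O)NC(C)C2=CC(=O)c3c(O)ccc(O)c3C2=O)cc1` share one core and have been measured, while compound 4 `CC(NS(=O)(=O)c1cccc(Br)c1)C1=CC(=O)c2c(O)ccc(O)c2C1=O` remains open. In a functional assay on HeLa cells (Homo sapiens) for cytotoxicity, read by sulforhodamine B assay (a lower number here means a stronger inhibitor, a higher number a weaker inhibitor), compound 1 gives 8950 nM, compound 2 gives 6650 nM and compound 3 gives 3760 nM. Compound 3 and compound 2 stand within the scatter of each other, and the only gap beyond the scatter in this set is modest: a 2.4-fold lower number from compound 1 to compound 3 (0.38 log units; beyond the scatter).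

The next step places 3-bromophenyl in place of 4-methoxyphenyl on a sulfonyl sulfur, (3-bromophenyl in place of 4-methoxyphenyl on a sulfonyl sulfur). The closest measured precedent is the other change made on this aromatic ring, a 1.3-fold lower number from compound 1 to compound 2 (0.13 log units; within the scatter), which stayed within the scatter. The chain change does not touch this ring, so it bears on the question only by setting the starting value. For the measured compounds named here, no measured compound carries 3-bromophenyl, which leaves the precedent thin and the range wide. No step beyond the scatter is therefore expected in this assay. The estimate corresponds to an expected 1.1-fold lower number from compound 3 to compound 4 (0.03 log units; within the scatter). Compound 4 is estimated at 3500 nM, with an expected range of 1600 nM to 7500 nM.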

Compound 4, half-maximal inhibitory concentration: 6350 nM
Beside the measured number, compound 4's estimate is 1.8-fold (0.26 log units) below it, within the range that was stated.
By their numbers in this assay, from the lowest: compounds 3, 4, 2 and 1 (each within the scatter of the next, the first and the last beyond it).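

At this position on a sulfonyl sulfur, the change to 3-bromophenyl in place of 4-methoxyphenyl gives a 1.7-fold higher number from compound 3 to compound 4 (0.23 log units; within the scatter) in this assay, so a second ring change, and the first on the methyl chain, also stays within the scatter. The earlier ring step, a 1.3-fold lower number from compound 1 to compound 2 (0.13 log units; within the scatter), was made on the isopropyl chain with fluoro in place of methoxy, so the two listed ring steps now cover both chains, and neither goes beyond the scatter; the new step also shows that a 4-methoxyphenyl group with 1 hydrogen-bond acceptor can give way to a 3-bromophenyl group with 0 without a step beyond the scatter, and no compound here goes against this reading. No measured evidence accounts for the size of this step.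

The compounds shown cover only aromatic rings carrying methoxy, fluoro or bromo on the sulfonyl sulfur, so it remains open whether an amine or a carboxylic acid on that ring would also stay within the scatter. Also open, from the compounds shown here alone, is whether a saturated alkyl chain in place of the aromatic ring on the sulfonyl sulfur would keep the number in this range.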